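This account rests on a few compounds, and the source may have more. Where it says the series, first, only, none or still open, it means among the compounds named here.

Working notes on the series. In a functional assay on HT-29 cells (Homo sapiens) for cytotoxicity, read by MTT assay, with a stated time of 72 h (a lower number here means a stronger inhibitor, a higher number a weaker inhibitor), compound 1 `COc1ccc(C(=O)c2cc(OC)c(OC)c(OC)c2)cc1N` gives 50 nM. Compound 2 `COc1cccc(/C=C/C(=O)Nc2cc(OC)c(OC)c(OC)c2)c1`, an amide on a trimethoxyaniline, gives 2400 nM in this assay. Compound 3 `COc1ccc(C(=O)c2cc(OC)c(OC)c(OC)c2)cc1NC(=O)/C=C/c1cc(OC)c(OC)c(OC)c1` joins the benzophenone of compound 1 to a cinnamamide. In this assay compound 3 gives 3100 nM. Compound 3 thus sits at the weak end of the three numbers: its gap to compound 2 lies within the scatter, while compound 1 sits far stronger, a gap well beyond the scatter.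

Compound 4 `COc1ccc(/C=C/C(=O)Nc2cc(C(=O)c3cc(OC)c(OC)c(OC)c3)ccc2OC)cc1` differs from compound 3 in one place: 4-methoxyphenyl in place of 3,4,5-trimethoxyphenyl on a double-bonded chain carbon bound to a double-bonded chain carbon. Within the data shown here, no measured pair shows this exact change on its own. Compound 2 and compound 3, which carry different aryl groups on the cinnamamide, sit within the scatter of each other, so the aryl swap is expected to give no step beyond the scatter, a 1.0-fold lower number from compound 3 to compound 4 (0.01 log units; within the scatter). Compound 4 is therefore estimated at 3000 nM in this assay, with a range from 1000 nM to 9000 nM.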

Compound 4, half-maximal inhibitory concentration: 5010 nM
Estimate against measurement, compound 4: 1.7-fold (0.22 log units) below; measured number inside the range.
By their numbers in this assay, from the lowest: compound 1; then compounds 2, 3 and 4 (each within the scatter of the next, the first and the last beyond it).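

In this assay, among these compounds, 4-methoxyphenyl in place of 3,4,5-trimethoxyphenyl on a double-bonded chain carbon bound to a double-bonded chain carbon gives a 1.6-fold higher number from compound 3 to compound 4 (0.21 log units; within the scatter), the first step that reads a single change on its own. At this position, then, going from 12 heavy atoms and 3 hydrogen-bond acceptors to 8 heavy atoms and 1 hydrogen-bond acceptor does not move the number beyond the scatter. Nothing at hand offers an explanation for this result.

Still open, going by these compounds, is whether a different kind of group on this aromatic ring, such as an amine or a carboxylic acid, would move the number beyond the scatter. Also open, on these data alone, is whether a plain unsubstituted phenyl at this place, or a longer chain carrying the ring, would do so.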